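The source may report more compounds than this note shows. Statements on the series, on what has been measured and on what is new or still open speak of the compounds shown alone.

Values in a functional assay (strain AB) with Danio rerio as the target, read by microscopy, with a stated time of 1 h; on this read-out higher numbers stand for an effect only at larger amounts of compound and lower numbers for an effect already at smaller amounts:
- Compound 1 `CC(C)(C)OC(=O)CCC[N+]1(C)CCc2c(sc(NC(=O)Nc3ccc(Cl)cc3)c2C(N)=O)C1`: 250 nM
- Compound 2 `CCN1CCc2c(sc(NC(=O)NCC3CCCO3)c2C(N)=O)C1`: > 25000 nM, a limit of the assay
- Compound 3 `CCN1CCc2c(sc(NC(=O)Nc3cccc(C#N)c3)c2C(N)=O)C1`: 10300 nM

Compound 1 has the lowest number here, and compound 3 at 10300 nM stands far higher. Compound 4 `C[N+]1(CC2CC2)CCc2c(sc(NC(=O)Nc3ccc(Cl)cc3)c2C(N)=O)C1` differs from compound 1 in one place: cyclopropyl in place of 2-(tert-butoxycarbonyl)ethyl on a saturated chain carbon bound to an amine nitrogen in a ring. Among the measured compounds shown here, the only measured step, an at least 2.4-fold lower number from compound 2 to compound 3 (0.38 log units; beyond the scatter), lies on an amide-type nitrogen, elsewhere in the structure, and gives no size for this place. The expectation therefore starts from compound 1 at 250 nM and stays cautious. A moderate move to a higher number in this assay is expected, estimated as a 2.0-fold higher number from compound 1 to compound 4 (0.30 log units; within the scatter). For compound 4 the expected value is 500 nM, with an estimated range of 80 nM to 4000 nM.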

Compound 4, half-maximal effective concentration: 360 nM
The estimate for compound 4 lay 1.4-fold (0.14 log units) above the measured number, and the stated range covers the measured number.
By their numbers in this assay, from the lowest: compounds 1 and 4 (each within the scatter of the next); then compound 3. At a limit, above all of these: compound 2.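

In this assay, replacing 2-(tert-butoxycarbonyl)ethyl with the smaller cyclopropyl, on a saturated chain carbon bound to an amine nitrogen in a ring, gives a 1.4-fold higher number from compound 1 to compound 4 (0.16 log units; within the scatter). At this place, then, the read-out tolerates losing the carbonyl group and both hydrogen-bond acceptors of the larger group. Nothing measured here explains this tolerance.

Still open, from the compounds shown here alone, is whether the place accepts groups of a different kind, such as a carboxylic acid or an amine. A longer plain carbon chain is equally untested among these compounds.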